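Swapping a benzyl amine for a dichlorobenzamide on the piperidine

The source may hold more compounds than are shown below. What is called first, only, known or untested is meant among the compounds shown, and "the series" means these compounds.

Measured so far:
compound 1, `COc1ccc2nccc(C3CN(C4CCN(Cc5ccccc5)CC4)C(=O)O3)c2c1`: 12600 nM
compound 2, `COc1ccc2nccc(C3CN(C4CCN(Cc5ccccc5Cl)CC4)C(=O)O3)c2c1`: < 50200 nM

In an in vitro functional assay on RBL cells for antagonist activity at C-C chemokine receptor type 8 (Homo sapiens), read by FLIPR and calcium flux (on this read-out lower numbers stand for stronger inhibition and higher numbers for weaker inhibition), compound 1 gives 12600 nM. For compound 2 this assay reports only a limit, < 50200 nM, not a number. The step that the limit leaves unreadable from compound 1 to compound 2 therefore cannot be sized, because the limit of < 50200 nM in this assay, at which 1 of the 2 values shown sits, is all that is known about compound 2 there.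

Compound 3 `COc1ccc2nccc(C3CN(C4CCN(C(=O)c5ccc(Cl)c(Cl)c5)CC4)C(=O)O3)c2c1` differs from compound 2 by (3,4-dichlorophenyl)carbonyl in place of 2-chlorobenzyl on an amine nitrogen in a ring. Among the compounds with values here, the only measured step concerns a different change and is unreadable, so no measured step bears on this one, and the expectation rests on compound 1 alone. Compound 3 is expected to sit near the level of compound 1, a weak inhibitor in this assay. The step that the limit leaves unreadable from compound 2 to compound 3 is accordingly expected to be of unknown direction. The estimate for compound 3 is 25000 nM, within 5000 nM to 100000 nM.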

Compound 3, half-maximal inhibitory concentration: 6310 nM
The estimate for compound 3 lay 4.0-fold (0.60 log units) above the measured number, and the stated range covers the measured number.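

The position on the amine nitrogen in a ring can take a (3,4-dichlorophenyl)carbonyl group in place of benzyl without a difference that can be told apart from noise in this assay: the result is a 2.0-fold lower number from compound 1 to compound 3 (0.30 log units; within the scatter). Within the data shown here, the earlier compounds showed no readable change at this nitrogen, so this is the first comparison there that yields a size. The step from compound 2 to compound 3 cannot be read, because compound 2 is known only by a limit: the limit of < 50200 nM in this assay, at which 1 of the 3 values shown sits.

This change swaps the link to the ring and adds chlorines at the same time, so the contribution of each stays unresolved. Also open, going by these compounds, is how this assay would read a plain benzoyl group with no chlorine, or a longer chain between the nitrogen and the aromatic ring.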